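This account rests on a few compounds, and the source may have more. Where it says the series, first, only, none or still open, it means among the compounds named here.

Three compounds built on a shared core have been examined in an ADME assay on Huh-7 cells (Homo sapiens) for cytotoxicity; on this read-out lower numbers stand for higher toxicity in this test and higher numbers for lower toxicity in this test. Compound 1 `COc1ccc(-n2cc(CNCCN3CCN(C)CC3)c(-c3ccccc3C)n2)cc1` gives > 20000 nM, which is a limit of the assay and not a number. Compound 2 `Cc1ccccc1-c1nn(-c2ccc(F)cc2F)cc1CNCCN1CCN(C)CC1` gives > 20000 nM, again a limit. Compound 3 `CN1CCN(CCNCc2cn(-c3ccc(F)cc3F)nc2C2CCCCC2)CC1` gives > 20000 nM, also a limit. The step that the two limits leave unreadable from compound 1 to compound 2, with 2,4-difluorophenyl in place of 4-methoxyphenyl on an aromatic nitrogen, cannot be sized. The step that the two limits leave unreadable from compound 2 to compound 3, with cyclohexyl in place of 2-methylphenyl on an aromatic carbon, is likewise unreadable. All three values sit at the limit of > 20000 nM in this assay, at which 3 of the 3 values shown sit. Compound 2 therefore stands at the limit, and the numbers at hand do not separate it from compounds 1 and 3.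

Compound 4 `CCCCCNCc1cn(-c2ccc(F)cc2F)nc1-c1ccccc1C` differs from compound 2 by propyl in place of 4-methylpiperazin-1-yl on a saturated chain carbon, two bonds along the chain from an amine nitrogen. Within the data shown here, no measured step touches this part of the molecule, and the two steps that are known give no readable size in either direction. Compound 4 is therefore expected to sit where the others do, with its value estimated at 25000 nM, within a range from 8000 nM to 80000 nM. The change this estimate implies is expected to read a step that the limit leaves unreadable from compound 2 to compound 4.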

Compound 4, half-maximal cytotoxic concentration: 17000 nM
Beside the measured number, compound 4's estimate is 1.5-fold (0.17 log units) above it; measured number inside the range.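

In this assay, among these compounds, compound 4 gives 17000 nM, the first number in this set, and the change from 4-methylpiperazin-1-yl to propyl at this place on the chain is the first that yields a step with even a lower bound on its size, an at least 1.1-fold lower number from compound 2 to compound 4 (0.07 log units; that floor lies within the scatter), whereas the earlier steps, at the aromatic nitrogen and the aromatic carbon, cannot be read. Compound 2 gives > 20000 nM, which is a limit of the assay and not a number. The floor of the step lies within the usual scatter, so the result does not establish that this change lowers the number, nor does it fix how large the step is, and most of the set remains at that limit (the limit of > 20000 nM in this assay, at which 3 of the 4 values shown sit).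

What the compounds shown leave open is whether a different group at this place, such as a morpholine, a dimethylamino group or a longer chain such as octyl, would give a number clearly apart from that of compound 4. They also leave open whether, with propyl in place, swapping the groups on the aromatic nitrogen and the aromatic carbon would produce steps that can be read.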